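The source may report more compounds than this note shows. Statements on the series, on what has been measured and on what is new or still open speak of the compounds shown alone.

Working notes on the series. Of the compounds shown here, two have been measured in an assay on isolated protein for inhibition of cytochrome P450 2A6 (Homo sapiens), read by fluorescence, with a stated time of 10 min; on this read-out lower numbers stand for stronger inhibition and higher numbers for weaker inhibition. For the measured compounds named here, compound 1, `CNCc1cc2cnccc2s1`, is the only member that returns a number: in this assay compound 1 gives 1500 nM. Compound 2, `NCc1cc2cc(Br)ccc2o1`, is built on a different core. In this assay compound 2 gives < 100000 nM, which is a limit of the assay and not a number. Going by the values given here, compound 2 thus stands at the limit of < 100000 nM in this assay, at which 1 of the 2 values shown sits, and no step between measured compounds can be drawn from it.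

Compound 3, `O=Cc1cc2cc(Br)ccc2o1`, has not been measured. Against compound 2 the change is formyl in place of aminomethyl on an aromatic carbon. Among the compounds with values here, no measured step covers a change of this kind, so neither its size nor its direction can be read from the numbers at hand. The step expected in this assay is a step that the limit leaves unreadable from compound 2 to compound 3, toward stronger inhibition, though with wide uncertainty. Compound 3 is expected to give 8000 nM, within a range from 800 nM to 80000 nM.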

Compound 3, half-maximal inhibitory concentration: 72000 nM
Compound 3: middle estimate off by 9.0-fold (0.95 log units), on the low side; measured number inside the range.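

For the compounds shown here, no step from compound 2 to compound 3 can be read in this assay, because the value of compound 2 is a limit of the assay and not a number: the limit of < 100000 nM in this assay, at which 1 of the 3 values shown sits. The compounds shown leave open the size and direction of the change in inhibition when formyl takes the place of aminomethyl on an aromatic carbon.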